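A Third Aryl Group on the Same Carbon

A few compounds are considered here, and "the series" means these few. Any claim that something is new, unique, unknown or untested is made for them only; others in the source may bear on it.

Compound 2 `CN(C)CCn1cnnc1-c1cc(Oc2ccc(NC(=O)N/N=C/c3ccc(F)cc3)cc2F)ccn1` is one of two compounds already tested in a functional assay on NCI-H460 cells (Homo sapiens) for cytotoxicity, read by MTT assay, with a stated time of 72 h; a higher number here means a weaker inhibitor, a lower number a stronger inhibitor. In this assay compound 2 gives 1980 nM, the higher of the two numbers, so it is the weaker inhibitor of the pair. Compound 1 `CN(C)CCn1cnnc1-c1cc(Oc2ccc(NC(=O)N/N=C/c3ccc(O)c(Br)c3)cc2F)ccn1` gives 430 nM in this assay. The two differ only in the aryl group on a carbon with a double bond to nitrogen, and that single swap produced a 4.6-fold higher number from compound 1 to compound 2 (0.66 log units; beyond the scatter).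

Compound 3 `COc1cc(/C=N/NC(=O)Nc2ccc(Oc3ccnc(-c4nncn4CCN(C)C)c3)c(F)c2)cc(OC)c1OC` has not yet been measured in this assay. It differs from compound 2 at the same place: 3,4,5-trimethoxyphenyl in place of 4-fluorophenyl on a carbon with a double bond to nitrogen. Among the measured compounds shown here, no measured step involves a 3,4,5-trimethoxyphenyl group, so there is no direct evidence for what it does. For the measured compounds named here, the one step on record, from compound 1 to compound 2, shows only that exchanging the aryl group on this carbon can shift the number by a modest amount. Compound 3 is therefore expected to give about 1200 nM in this assay, within a range from 350 nM to 4000 nM. That expectation corresponds to a 1.7-fold lower number from compound 2 to compound 3 (0.22 log units; within the scatter), a step that may stay within the scatter.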

Compound 3, half-maximal inhibitory concentration: 2770 nM
For compound 3 the middle estimate is 2.3-fold (0.36 log units) below the measured one; the measured number falls inside the stated range.
By their numbers in this assay, from the lowest: compound 1; then compounds 2 and 3 (each within the scatter of the next).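

In this assay, putting 3,4,5-trimethoxyphenyl in place of 4-fluorophenyl on this carbon gives a 1.4-fold higher number from compound 2 to compound 3 (0.15 log units; within the scatter) and so leaves the two compounds indistinguishable, even though the entering group has 12 heavy atoms and 3 hydrogen-bond acceptors, while the leaving group has 7 heavy atoms and 0 hydrogen-bond acceptors. The comparison with 3-bromo-4-hydroxyphenyl gives a 6.4-fold higher number from compound 1 to compound 3 (0.81 log units; beyond the scatter) and lies beyond the scatter, as the earlier step did, so among these three compounds only compound 1 stands apart, as the strongest inhibitor. Nothing available here accounts for why this aryl group differs from the other two.

Going by these compounds, the bromine and the hydroxyl group appear only together in compound 1, so it remains open whether either one alone would go with a number as low as that of compound 1. Also open is what this carbon would tolerate beyond the three aryl groups shown, for example a phenyl ring carrying an amine or a carboxylic acid, or a longer chain in place of the ring.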